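Dropping the Chloro from a Biaryl Salicylanilide

The compounds below may be only part of what the source reports. "The series", "measured", "known", "first", "only" and "open" are said of these compounds alone.

Measured compounds:
compound 2, `N#Cc1ccc(NC(=O)c2cc(Cl)c(-c3ccccc3)cc2O)cc1`, 520 nM
compound 1, `COc1ccc(C(=O)Nc2ccc(C#N)cc2)c(O)c1`, 5470 nM

In a functional assay on HL-60 cells (Homo sapiens) for cytotoxicity, read by luminescence and CellTiter-Glo, with a stated time of 3 days (on this read-out higher numbers stand for weaker inhibition and lower numbers for stronger inhibition), compound 2 gives 520 nM, the lowest of the two numbers in hand. Compound 1 sits well apart from it: in this assay compound 1 gives 5470 nM, a gap beyond the scatter. The two structures differ in more than one place, so the gap cannot be assigned to any single group.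

Compound 3, `N#Cc1ccc(NC(=O)c2ccc(-c3ccccc3)cc2O)cc1`, takes one step away from compound 2: hydrogen in place of chloro on an aromatic carbon. Nothing in the two measured values isolates the contribution of the chloro on its own, so the expectation rests on the general experience that losing a halogen from an aromatic ring of this kind usually costs some potency, but rarely a great deal. A modest move toward weaker inhibition is therefore expected, probably just beyond the scatter. The expected step is a 2.3-fold higher number from compound 2 to compound 3 (0.36 log units; beyond the scatter). For compound 3 the estimate in this assay is 1200 nM, with a range from 500 nM to 3500 nM.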

Compound 3, half-maximal inhibitory concentration: 700 nM
The estimate for compound 3 lay 1.7-fold (0.23 log units) above the measured number; measured number inside the range.
By their numbers in this assay, from the lowest: compounds 2 and 3 (each within the scatter of the next); then compound 1.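

In this assay, the chloro on the aromatic carbon para to a hydroxy group shows no measurable weight: hydrogen in its place gives a 1.3-fold higher number from compound 2 to compound 3 (0.13 log units; within the scatter), so compound 2 and compound 3 cannot be told apart on these numbers. Removing the chloro also links compound 3 to compound 1 by a single change, phenyl in place of methoxy on an aromatic carbon, and this change gives a 7.8-fold lower number from compound 1 to compound 3 (0.89 log units; beyond the scatter), so among these three compounds the large gap that could not be assigned earlier goes with the phenyl group and not with the chloro. No measurement at hand speaks to the reason for either step.

Going by these compounds, it remains open whether the carbon that held the chloro would accept a different group, such as an amine or a carboxylic acid, and whether a cyclohexyl group could stand in for the phenyl. On these data alone, the nitrile and the hydroxy group are present in all three compounds, so their share in the numbers, and the effect of replacing the hydroxy group with an amine, also remain unknown.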